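Methoxy Added to a Trimethoxy Chalcone: an Expected Loss

The source may report more compounds than this note shows. Statements on the series, on what has been measured and on what is new or still open speak of the compounds shown alone.

Compound 1 `COc1ccc(/C=C/C(=O)c2ccccc2-c2ccc(F)nc2)cc1`: 330 nM in a functional assay on SW480 cells (Homo sapiens) for antiproliferative activity, read by sulforhodamine B assay, with a stated time of 48 h; on this read-out higher numbers stand for weaker inhibition and lower numbers for stronger inhibition
Compound 2 `COc1ccc(/C=C/C(=O)c2ccccc2-c2ccc(F)nc2)cc1OC`: 1300 nM
Compound 3 `COc1ccc(C(=O)/C=C/c2ccccc2-c2ccc(F)cc2)cc1OC`: 8300 nM

For the measured compounds named here, the one change measured here is methoxy in place of hydrogen on an aromatic carbon, and it gave a 3.9-fold higher number from compound 1 to compound 2 (0.60 log units; beyond the scatter). Compound 3 stands highest of the three; its nearest neighbour is compound 2, and compound 1 lies furthest from it. The difference between the core of compound 1 and the core of compound 3 is not broken down here.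

Compound 4 `COc1cc(C(=O)/C=C/c2ccccc2-c2ccc(F)cc2)cc(OC)c1OC` has not yet been measured. It arises from compound 3 by methoxy in place of hydrogen on an aromatic carbon. Going by the values given here, this is the same kind of change as the one from compound 1 to compound 2, not the same change: in compound 4 the entering methoxy is also meta to a methoxy group, which it is not in compound 2. Since the earlier step of this kind was a 3.9-fold higher number from compound 1 to compound 2 (0.60 log units; beyond the scatter), a step of similar size is expected from compound 3 to compound 4, namely a 2.7-fold higher number from compound 3 to compound 4 (0.42 log units; beyond the scatter). Compound 4 is therefore estimated at 22000 nM in this assay, within a range from 7000 nM to 70000 nM.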

Compound 4, half-maximal inhibitory concentration: 2200 nM
Estimate against measurement, compound 4: 10-fold (1.00 log units) above, and the stated range ends above it.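

The added methoxy gave a 3.8-fold lower number from compound 3 to compound 4 (0.58 log units; beyond the scatter) in this assay and so ran against the earlier step of this kind, which shows that in this series the change did not carry its effect from one core to the other: the same change on two cores in this assay, a 3.9-fold higher number (0.60 log units; beyond the scatter) from compound 1 to compound 2 and a 3.8-fold lower number (0.58 log units; beyond the scatter) from compound 3 to compound 4, 15-fold (1.17 log units) apart, beyond the scatter of two such steps. This does not show that the core alone decides the direction, since the entering methoxy is meta to a methoxy group in compound 4 but not in compound 2, and the two steps therefore differ in its surroundings as well. Two steps also give no rule for any further core, and they do not say what lies behind the reversal.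

The compounds shown leave open what a third methoxy group would do on the core of compound 1, which would separate the core from the surroundings of the entering group. They also leave open whether a hydroxyl or an ethoxy group in the same place would follow the methoxy on either core.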